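A few compounds are considered here, and "the series" means these few. Any claim that something is new, unique, unknown or untested is made for them only; others in the source may bear on it.

Going by the values given here, in an ADME assay on J774.A1 cells (Mus musculus) for cytotoxicity, read by MTT assay, with a stated time of 72 h (on this read-out higher numbers stand for lower toxicity in this test and lower numbers for higher toxicity in this test), compound 3 `CC1(c2ccccc2)CC(S(=O)(=O)c2ccc(F)cc2)=C(c2ccc(/C(N)=N\O)cc2)O1` gives 29700 nM, the highest of the numbers measured so far in this small set. Compound 2 `CC1(c2ccc(-c3ccccc3C#N)cc2)CC(S(=O)(=O)c2ccc(F)cc2)=C(c2ccc(/C(N)=N\O)cc2)O1` gives 9290 nM, and compound 1 `CC1(c2ccc(-c3ccc(/C(N)=N\O)cc3)cc2)CC(S(=O)(=O)c2ccc(F)cc2)=C(c2ccc(/C(N)=N\O)cc2)O1` gives 3940 nM.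

The next compound, compound 4 `CC1(c2ccc(-c3cccc([N+](=O)[O-])c3)cc2)CC(S(=O)(=O)c2ccc(F)cc2)=C(c2ccc(/C(N)=N\O)cc2)O1`, differs from compound 3 at a single place: 3-nitrophenyl in place of hydrogen on an aromatic carbon. In words, this is 3-nitrophenyl in place of hydrogen on an aromatic carbon, para to a large group.

Among the compounds with values here, two measured steps bear on this change, and both remove a substituted phenyl group: a 3.2-fold higher number from compound 2 to compound 3 (0.50 log units; beyond the scatter) and a 7.5-fold higher number from compound 1 to compound 3 (0.88 log units; beyond the scatter). Read in reverse, each has a substituted phenyl group entering and the number falling. Neither measured compound goes against this, but the evidence is only these two compounds. The size depends on the entering group, as a 2.4-fold higher number from compound 1 to compound 2 (0.37 log units; beyond the scatter) shows. The 3-nitrophenyl group is closer in heavy-atom count to the 2-cyanophenyl group of compound 2, so the smaller step, a 3.2-fold higher number from compound 2 to compound 3 (0.50 log units; beyond the scatter), is the better guide. A fall beyond the scatter is therefore expected in this assay. The estimated step is a 3.3-fold lower number from compound 3 to compound 4 (0.52 log units; beyond the scatter). For compound 4 the estimated value is 9000 nM, with an expected range of 4000 nM to 20000 nM.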

Compound 4, half-maximal cytotoxic concentration: 11100 nM
The estimate for compound 4 lay 1.2-fold (0.09 log units) below the measured number; the measured number falls inside the stated range.
By their numbers in this assay, from the lowest: compound 1; then compounds 2 and 4 (each within the scatter of the next); then compound 3.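

In this assay, a third substituted phenyl group on this aromatic carbon, para to a large group, again gives a lower number than hydrogen, a 2.7-fold lower number from compound 3 to compound 4 (0.43 log units; beyond the scatter), so all three substituted compounds now lie below compound 3, and none goes against this. The exchange of 2-cyanophenyl for 3-nitrophenyl leaves no readable difference, a 1.2-fold higher number from compound 2 to compound 4 (0.08 log units; within the scatter), while the group carried by compound 1 remains distinct from 3-nitrophenyl, a 2.8-fold higher number from compound 1 to compound 4 (0.45 log units; beyond the scatter), so the size of the fall depends on the entering group, though not on every change of that group. No measurement available here bears on the reason for these steps.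

On these data alone, whether the fall comes with the phenyl ring itself or with its substituent remains open, and an unsubstituted phenyl group on this carbon would separate the two. As far as these compounds go, it is also open whether a group without a ring, such as a methyl group, an amine or a carboxylic acid, would give a number nearer that of compound 3 or nearer those of the compounds carrying a substituted phenyl group.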